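The compounds below may be only part of what the source reports. "The series", "measured", "known", "first", "only" and "open" are said of these compounds alone.

Three compounds that share one core and differ only in the group on an oxygen on a saturated carbon have been tested in a functional assay with Homo sapiens as the target; a lower number here means a stronger inhibitor, a higher number a weaker inhibitor. Compound 1 `CC(C)[C@H](NC(=O)COc1cccc2ccccc12)C(=O)N[C@@H](CC(=O)O)C(=O)COc1ccc2ccccc2c1`, with naphthalen-2-yl there, gives 15900 nM. Compound 2 `CC(C)[C@H](NC(=O)COc1cccc2ccccc12)C(=O)N[C@@H](CC(=O)O)C(=O)COc1ccc(-c2ccccc2)cc1`, with 4-phenylphenyl, gives 38700 nM. Compound 3 `CC(C)[C@H](NC(=O)COc1cccc2ccccc12)C(=O)N[C@@H](CC(=O)O)C(=O)COc1c(F)c(F)cc(F)c1F`, with 2,3,5,6-tetrafluorophenyl, gives 6250 nM, the lowest number of the three and so the strongest inhibitor in this small set.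

For the measured compounds named here, the next compound, compound 4 `CC(C)[C@H](NC(=O)COc1cccc2ccccc12)C(=O)N[C@@H](CC(=O)O)C(=O)COc1c(Cl)cccc1Cl`, changes only this group, with 2,6-dichlorophenyl in place of 2,3,5,6-tetrafluorophenyl on an oxygen on a saturated carbon. Going by the values given here, no compound with chlorine has been measured yet, so the evidence is indirect. The three measured swaps at this place are all modest: a 2.4-fold higher number from compound 1 to compound 2 (0.39 log units; beyond the scatter), a 2.5-fold lower number from compound 1 to compound 3 (0.41 log units; beyond the scatter) and a 6.2-fold lower number from compound 2 to compound 3 (0.79 log units; beyond the scatter). A step of similar modest size therefore seems reasonable. An upward direction seems somewhat more likely, as compound 3, at 6250 nM, already sits at the low end, though this is a weak guide. The expected change is a 2.1-fold higher number from compound 3 to compound 4 (0.32 log units; beyond the scatter). For compound 4 the estimated value is 13000 nM, with an expected range from 5000 nM to 32000 nM.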

Compound 4, half-maximal inhibitory concentration: 15300 nM
For compound 4 the middle estimate is 1.2-fold (0.07 log units) below the measured one, and the stated range covers the measured number.
By their numbers in this assay, from the lowest: compound 3; then compounds 4 and 1 (each within the scatter of the next); then compound 2.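

In this assay, the only chlorine-bearing group shown does not match the tetrafluorinated ring (a 2.4-fold higher number from compound 3 to compound 4 (0.39 log units; beyond the scatter)), so halogens on this ring are not interchangeable here, and compound 3 remains the strongest inhibitor of the four. The 2,6-dichlorophenyl group instead gives a result matching that of the much larger-looking naphthalen-2-yl group (a 1.0-fold lower number from compound 1 to compound 4 (0.02 log units; within the scatter)), which shows that two quite different groups at this position can give the same number, while compound 2 stays the weakest of the set (a 2.5-fold lower number from compound 2 to compound 4 (0.40 log units; beyond the scatter)). Nothing available explains this order, as no measurement bearing on it is at hand.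

As far as these compounds go, it remains open whether a 2,6-difluorophenyl or a 2,6-dimethylphenyl group would fall nearer compound 3 or compound 4, which would help separate the effect of the kind of substituent from that of its number. From the compounds shown here alone, all four compounds also keep the shared core, so it is equally open whether this order would hold with an amide in place of the carboxylic acid.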